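Dropping the Methoxy from Compound 1: Expected Solubility

This account rests on a few compounds, and the source may have more. Where it says the series, first, only, none or still open, it means among the compounds named here.

Compound 1 `COc1ccc(NC[C@H](O)COc2ccc(N3C[C@H](CNC(C)=O)OC3=O)cc2F)cc1`: 56000 nM
Compound 2 `COc1ccc(NC[C@@H](O)COc2ccc(N3C[C@H](CNC(C)=O)OC3=O)cc2F)cc1`: 1300 nM

Among the compounds with values here, in a physicochemical assay for solubility, read by HPLC (on this read-out higher numbers stand for higher solubility and lower numbers for lower solubility), compound 1 stands highest of the two numbers measured so far. Within the data shown here, the only measured step, a 43-fold lower number from compound 1 to compound 2 (1.63 log units; beyond the scatter), is large, and the two compounds differ in nothing but (the fact that compounds 1 and 2 differ only in the configuration as drawn).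

Compound 3 `CC(=O)NC[C@H]1CN(c2ccc(OC[C@@H](O)CNc3ccccc3)c(F)c2)C(=O)O1` is compound 1 with a different change: hydrogen in place of methoxy on an aromatic carbon. Among the measured compounds shown here, the step from compound 1 to compound 2 turns on configuration alone and so says nothing about removing a methoxy group; no measured step bears on this change. With nothing pointing either way, no step beyond the usual scatter is expected, and the estimate stays near compound 1 with a wide range.

Compound 3 is therefore expected to give about 45000 nM (between 15000 nM and 130000 nM), which means an expected 1.2-fold lower number from compound 1 to compound 3 (0.09 log units; within the scatter).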

Compound 3, solubility: 124000 nM
Beside the measured number, compound 3's estimate is 2.8-fold (0.44 log units) below it; the measured number falls inside the stated range.
By their numbers in this assay, from the lowest: compound 2; then compound 1; then compound 3.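

In this assay, the change of hydrogen in place of methoxy on an aromatic carbon, para to a large group, now has a measured size: a 2.2-fold higher number from compound 1 to compound 3 (0.35 log units; beyond the scatter), a modest step that lies beyond the usual scatter. The 4-methoxyphenyl group of compound 1 can therefore give way to plain phenyl with the number rising, not falling, and this step is smaller than the one that configuration alone produced, a 43-fold lower number from compound 1 to compound 2 (1.63 log units; beyond the scatter). Within the data shown here, nothing measured so far accounts for the direction or size of the methoxy step.

On these data alone, whether a chloro group or an amine at the same place would lift the number further remains open. So does whether removing the methoxy from compound 2 would give a step of similar size.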